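Fluoro on the indole of the methyl compound

A few compounds are considered here, and "the series" means these few. Any claim that something is new, unique, unknown or untested is made for them only; others in the source may bear on it.

Measured in an ADME assay on HEK293 cells (Homo sapiens) for cytotoxicity, read by MTT assay, with a stated time of 72 h; on this read-out higher numbers stand for weaker inhibition and lower numbers for stronger inhibition:
- compound 1 (`COc1ccc(C(=O)N2CCN(CC(=O)N3CCN(CCCc4c[nH]c5ccccc45)CC3)CC2)cc1`) gives 156000 nM
- compound 2 (`O=C(CN1CCN(C(=O)c2ccc(Br)cc2)CC1)N1CCN(CCCc2c[nH]c3ccccc23)CC1`) gives 71900 nM
- compound 3 (`Cc1ccc(C(=O)N2CCN(CC(=O)N3CCN(CCCc4c[nH]c5ccccc45)CC3)CC2)cc1`) gives 159000 nM

Compound 3 shares the upper end of these three numbers with compound 1, the step being a 1.0-fold higher number from compound 1 to compound 3 (0.01 log units; within the scatter). For the measured compounds named here, the only steps beyond the scatter involve the bromo group, namely a 2.2-fold lower number from compound 1 to compound 2 (0.34 log units; beyond the scatter) and a 2.2-fold higher number from compound 2 to compound 3 (0.34 log units; beyond the scatter).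

Compound 4 (`Cc1ccc(C(=O)N2CCN(CC(=O)N3CCN(CCCc4c[nH]c5ccc(F)cc45)CC3)CC2)cc1`) carries fluoro in place of hydrogen on an aromatic carbon, 1H-indol-3-yl becoming 5-fluoro-1H-indol-3-yl (fluoro in place of hydrogen on an aromatic carbon). Going by the values given here, no measured step touches this place, since all three exchange groups on a different aromatic carbon, so they bear on it only indirectly. Even the largest of them is modest, which argues for expecting little movement in this assay here, with no step beyond the scatter. The expected change is a 1.2-fold lower number from compound 3 to compound 4 (0.09 log units; within the scatter). The estimate for compound 4 is 130000 nM, with an expected range from 70000 nM to 220000 nM.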

Compound 4, half-maximal inhibitory concentration: 141000 nM
Compound 4: middle estimate off by 1.1-fold (0.04 log units), on the low side; measured number inside the range.
By their numbers in this assay, from the lowest: compounds 2, 4, 1 and 3 (each within the scatter of the next, the first and the last beyond it).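

In this assay, for the compounds shown here, the 5-fluoro-1H-indol-3-yl group of compound 4 and the 1H-indol-3-yl group of compound 3 cannot be told apart, with a 1.1-fold lower number from compound 3 to compound 4 (0.05 log units; within the scatter) as the only step read at this place. Going by these compounds alone, this gives the indole side of the series a direct reading for the first time, as the earlier steps all lay on a different aromatic carbon, but it holds only for fluoro in place of hydrogen alongside the methyl group. No measurement given here bears on the reason for this result.

On these data alone, whether chloro, a nitrile or an amine on the same aromatic carbon would stay equally close to compound 3 remains open. Also open, as far as these compounds go, is whether fluoro at this place would read the same alongside the bromo group of compound 2.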